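The compounds below may be only part of what the source reports. "The series", "measured", "known", "first", "only" and "open" are said of these compounds alone.

Measured so far in an assay on HEK293 cells for agonist activity at transient receptor potential cation channel subfamily M member 8 (Homo sapiens), read by fluorescence and calcium flux, with a stated time of 15 min; on this read-out higher numbers stand for an effect only at larger amounts of compound and lower numbers for an effect already at smaller amounts:
compound 1 `CCN(Cc1cc[nH]n1)C(=O)COc1ccc(C)cc1`, "not active" (no number reported)
compound 2 `CCN(Cc1cccs1)C(=O)C(C)Oc1ccc(C)cc1`, 889 nM
compound 3 `Cc1ccc(OCC(=O)N(Cc2cccs2)C(C)(C)C)cc1`, 11000 nM

Compound 1 stands without a number: in this assay compound 1 is reported as "not active" (no number reported), so no single value places it against compound 2 or compound 3, which both give numbers in this assay. Compound 4 `CCN(Cc1ccncc1)C(=O)COc1ccc(C)cc1` differs from compound 1 in one place: pyridin-4-yl in place of 1H-pyrazol-3-yl on a saturated chain carbon bound to an amide-type nitrogen. Going by the values given here, no measured pair shows this difference, so the size of the step is open. Given that compound 2 and compound 3 carry numbers in this assay while compound 1 does not, the expectation for compound 4 is that this assay reports a number rather than none, with an effect only at larger amounts than for compound 2. Compound 4 is expected at 5000 nM, within 1000 nM to 30000 nM.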

Compound 4, half-maximal effective concentration: "not active" (no number reported)
Nothing numeric was reported for compound 4, and the estimate cannot be compared.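

Compound 1 and compound 4 both come without a number, so no step can be read between them. The compounds shown leave open whether this assay gives a number for any compound carrying (1H-pyrazol-3-yl)methyl or (pyridin-4-yl)methyl. No further data shown bear on this result.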